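The source may hold more compounds than are shown below. What is called first, only, known or untested is meant among the compounds shown, and "the series" means these compounds.

Measured compounds:
- compound 1 `Nc1nc(N)c2cc(CSC(=S)N3CCN(c4ccc(O)cc4)CC3)ccc2n1`: 5180 nM
- compound 2 `Cc1ccc(N2CCN(C(=S)SCc3ccc4nc(N)nc(N)c4c3)CC2)cc1`: 2130 nM
- compound 3 `Nc1nc(N)c2cc(CSC(=S)N3CCN(c4ccccc4Cl)CC3)ccc2n1`: 4050 nM

In a functional assay on HeLa cells (Homo sapiens) for antiproliferative activity, read by MTT assay, with a stated time of 72 h (on this read-out higher numbers stand for weaker inhibition and lower numbers for stronger inhibition), compound 1 gives the highest number of the three. Its nearest neighbour is compound 3, which differs by a 1.3-fold lower number from compound 1 to compound 3 (0.11 log units; within the scatter). The largest gap is to compound 2, with a 2.4-fold lower number from compound 1 to compound 2 (0.39 log units; beyond the scatter). Between compound 2 and compound 3 the step is a 1.9-fold higher number from compound 2 to compound 3 (0.28 log units; within the scatter).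

Compound 4 `Nc1nc(N)c2cc(CSC(=S)N3CCN(c4ccc(Cl)c(Cl)c4)CC3)ccc2n1` has not been measured. It differs from compound 1 by 3,4-dichlorophenyl in place of 4-hydroxyphenyl on an amine nitrogen in a ring.

Within the data shown here, two measured steps bear on this change. Both replace the hydroxy-bearing ring of compound 1 with a ring lacking the hydroxy group: a 2.4-fold lower number from compound 1 to compound 2 (0.39 log units; beyond the scatter) and a 1.3-fold lower number from compound 1 to compound 3 (0.11 log units; within the scatter). Both point the same way, one beyond the scatter and one within it. Compound 4 also removes the hydroxy group and adds chlorine, so a modest lowering in this assay is expected, of roughly the size seen in the measured steps. The step expected is a 1.9-fold lower number from compound 1 to compound 4 (0.28 log units; within the scatter). Compound 4 is therefore estimated at 2700 nM, with a range from 1200 nM to 6000 nM.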

Compound 4, half-maximal inhibitory concentration: 3060 nM
For compound 4 the middle estimate is 1.1-fold (0.05 log units) below the measured one, and the stated range covers the measured number.
By their numbers in this assay, from the lowest: compounds 2, 4, 3 and 1 (each within the scatter of the next, the first and the last beyond it).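

In this assay, a ring with two chlorines and no hydroxy group gives a 1.7-fold lower number from compound 1 to compound 4 (0.23 log units; within the scatter), so this third replacement on the amine nitrogen in a ring again leaves the number close to that of the 4-hydroxyphenyl compound. The 3,4-dichlorophenyl group also stands close to the other two replacements, with a 1.3-fold lower number from compound 3 to compound 4 (0.12 log units; within the scatter) and a 1.4-fold higher number from compound 2 to compound 4 (0.16 log units; within the scatter), so the new compound does not separate the chlorine-bearing and methyl-bearing rings, and the step from compound 1 to compound 2 remains the only one beyond the scatter. No measurement shown here accounts for these small differences.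

On these data alone, what remains open is whether anything other than a substituted phenyl ring, such as a pyridine, a cyclohexyl group or a benzyl group, would change the number by more at this nitrogen. Also open, as far as these compounds go, is the effect of a carboxylic acid or an amine on the phenyl ring.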